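The compounds below may be only part of what the source reports. "The series", "measured", "known", "first", "only" and "open" are said of these compounds alone.

Measured so far in a functional assay on SF-295 cells (Homo sapiens) for inhibition, read by sulforhodamine B assay, with a stated time of 48 h; on this read-out higher numbers stand for weaker inhibition of growth and lower numbers for stronger inhibition of growth:
- compound 1 `O=C(Cc1csc2nc(-c3ccc(Br)cc3)cn12)N/N=C/c1ccccc1`: 12000 nM
- compound 2 `O=C(Cc1csc2nc(-c3ccc(Br)cc3)cn12)N/N=C/c1ccccc1O`: 2750 nM

Compound 2, at 2750 nM, holds the lower of the two numbers, so it is the stronger growth inhibitor of this pair. Compound 3 `O=C(Cc1csc2nc(-c3ccc(Br)cc3)cn12)N/N=C/c1ccc(O)cc1` has not yet been measured in this assay. It has the same atoms as compound 2, joined differently: 4-hydroxyphenyl in place of 2-hydroxyphenyl on a carbon with a double bond to nitrogen. In words, this is 4-hydroxyphenyl in place of 2-hydroxyphenyl on a carbon with a double bond to nitrogen.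

Among the compounds with values here, only one measured step bears on this change: a 4.4-fold lower number from compound 1 to compound 2 (0.64 log units; beyond the scatter), with hydroxy in place of hydrogen on an aromatic carbon. Compound 3 also carries a hydroxy, so some of that modest gain is expected to remain. Within the data shown here, no measured pair yet shows what moving the hydroxy does, so the expectation is uncertain and the range is wide. The estimate is a 1.6-fold higher number from compound 2 to compound 3 (0.21 log units; within the scatter), a small expected rise in the number. Compound 3 is expected at about 4500 nM, with an estimated range of 1500 nM to 13000 nM.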

Compound 3, concentration for 50% growth inhibition: 12000 nM
For compound 3 the middle estimate is 2.7-fold (0.43 log units) below the measured one; measured number inside the range.
By their numbers in this assay, from the lowest: compound 2; then compounds 1 and 3 (each within the scatter of the next).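

In this assay, moving the hydroxy around the ring gives a 4.4-fold higher number from compound 2 to compound 3 (0.64 log units; beyond the scatter), so on this aryl group the place of the hydroxy counts, and not only its presence. The 4-hydroxyphenyl group, set against the plain phenyl, gives no change at the digits printed from compound 1 to compound 3 (within the scatter), which means that the earlier gain from adding a hydroxy does not carry over to every placement and, among these three compounds, appears only with 2-hydroxyphenyl. Nothing available here accounts for this difference.

From the compounds shown here alone, it remains open whether the hydroxy itself is needed in the position it holds in compound 2, or whether another group there, such as a methoxy or an amine, would give a similar number. Going by these compounds, it is also open whether the difference between 2-hydroxyphenyl and 4-hydroxyphenyl would persist if the bromine on the shared core were replaced by another group, such as chlorine or a methoxy.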